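A few compounds are considered here, and "the series" means these few. Any claim that something is new, unique, unknown or untested is made for them only; others in the source may bear on it.

Of the compounds shown here, two that share one core have so far been measured in a functional assay on the whole organism (strain Wistar) for inhibition, with Rattus norvegicus as the target, read by paw edema, with a stated time of 1 h, at a dose of 100 mg/kg; a lower number here means less inhibition, a higher number more inhibition at the dose given (going by the name of the read-out). Compound 1 `COc1cc2c(cc1OC)C(CC(=O)O)CC2` carries a hydroxy group on a carbonyl carbon and gives 18.8%. Compound 2 `COc1cc2c(cc1OC)C(CC(=O)Nc1ccc(C)cc1)CC2` carries a (4-methylphenyl)amino group in place of that hydroxy group and gives 34.4%. Among the measured compounds shown here, the single measured step, a number 15.6 percentage points higher from compound 1 to compound 2 (beyond the scatter), leaves compound 2 standing highest of the two numbers, with compound 1 a modest distance lower.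

Compound 3 `COc1cc2c(cc1OC)C(CC(=O)Nc1ccncc1)CC2` is the compound still to be measured, and its difference from compound 2 is pyridin-4-yl in place of 4-methylphenyl on an amide-type nitrogen. This change keeps the amide in place and alters only the ring attached to the amide-type nitrogen. For the measured compounds named here, no measured step speaks to a change of this kind: the one step recorded concerns the amide itself, not which ring sits on its nitrogen. With only the value of compound 2 as a starting point, the expected step is a number 2.4 percentage points lower from compound 2 to compound 3 (within the scatter), small enough that it may well stay within the scatter. Compound 3 is therefore expected to give about 32% in this assay, most likely between 18% and 48%.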

Compound 3, a percentage reported as inhibition, in the whole organism at one dose (the size of the read-out at that dose, not a potency): 42.2%
Compound 3: middle estimate off by 10.2 percentage points, on the low side; measured number inside the range.
By their numbers in this assay, from the lowest: compound 1; then compounds 2 and 3 (each within the scatter of the next).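

In this assay, the exchange on the amide-type nitrogen gives a number 7.8 percentage points higher from compound 2 to compound 3 (within the scatter), so the ring there can hold one ring nitrogen in place of a carbon, and lose the methyl group, without a difference that can be told apart from ordinary variation between repeat measurements. The replacement of the hydroxy group on the carbonyl carbon now has a second example, a number 23.4 percentage points higher from compound 1 to compound 3 (beyond the scatter), which means that both amides shown, carrying quite different rings, stand clearly apart from the carboxylic acid compound 1 . Nothing available gives a reason for either step, or says what the pyridine nitrogen does here.

The two rings shown on this nitrogen are both six-membered and aromatic, so it remains open whether the difference from compound 1 needs such a ring at all, or whether a cyclohexyl ring or a plain ethyl chain would serve as well. These numbers are also sizes of effect at a single dose, not potencies, so a difference between compound 2 and compound 3 at other doses remains an open question.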